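The source may report more compounds than this note shows. Statements on the series, on what has been measured and on what is new or still open speak of the compounds shown alone.

Compound 1 (`COC(=O)c1c(NCc2ccc(OC)cc2)noc1-c1ccc([N+](=O)[O-])cc1`), compound 2 (`COC(=O)c1c(NCc2ccc(C(C)(C)C)cc2)noc1-c1ccc([N+](=O)[O-])cc1`), compound 3 (`COC(=O)c1c(NCc2ccc(OC)c(OC)c2)noc1-c1ccc([N+](=O)[O-])cc1`) and compound 4 (`CCN(CC)CCNc1noc(-c2ccc([N+](=O)[O-])cc2)c1C(=O)OC`) share one core and differ in the group on the amine nitrogen. In an ADME assay on J774.A1 cells (Mus musculus) for cytotoxicity, read by MTT assay, with a stated time of 48 h (on this read-out lower numbers stand for higher toxicity in this test and higher numbers for lower toxicity in this test), compound 3 has the entry "not determined" (no result reported) and therefore no single number. Compound 1 is in the same position, with the entry "not determined" (no result reported) on record. Among the measured compounds shown here, only compound 2 has a measured number, at 81400 nM in this assay so far. Compound 3 therefore cannot be ranked against it.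

The step to compound 4 is large in structure: (diethylamino)methyl in place of 3,4-dimethoxyphenyl on a saturated chain carbon bound to a nitrogen on an aromatic ring. Put in words, (diethylamino)methyl stands in place of 3,4-dimethoxyphenyl on a saturated chain carbon bound to a nitrogen on an aromatic ring. For the measured compounds named here, no measured pair shows what a change at this place does, and compound 3 offers no starting value. Going by the values given here, the only anchor is compound 2 at 81400 nM on this read-out, and it is a weak one. From that anchor, a modest step toward lower numbers, meaning higher toxicity, is expected, though it may not clear the usual scatter. In this assay compound 4 is expected at 60000 nM within an estimated range of 18000 nM to 200000 nM for now.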

Compound 4, half-maximal cytotoxic concentration: 69300 nM
Compound 4: the middle estimate sits 1.2-fold (0.06 log units) below what was measured, and the stated range covers the measured number.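

In this assay, among the compounds shown here, putting (diethylamino)methyl in place of 4-(tert-butyl)phenyl on a saturated chain carbon bound to a nitrogen on an aromatic ring gives the first step that can be read at this position: a 1.2-fold lower number from compound 2 to compound 4 (0.07 log units; within the scatter). For the compounds shown here, this single pair shows that a group with no ring and a group carrying a six-membered aromatic ring of carbon can stand at this place without the two compounds being told apart on this read-out, whereas the earlier compounds offered only one number and so no comparison at all. The steps involving compound 1 or compound 3 cannot be read, and nothing on hand explains why the exchange leaves the two values so close.

The compounds shown leave open whether this holds for other groups at the same place, such as a piperidine, a carboxylic acid or a longer chain ending in an amine. They also leave open whether a change elsewhere on the shared core, such as a carboxylic acid in place of the methyl ester, would move the number beyond the usual scatter of this test.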